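Amide tail trimming in the shared pyrazole series

This account rests on a few compounds, and the source may have more. Where it says the series, first, only, none or still open, it means among the compounds named here.

Measured so far:
Compound 1 `COc1cc(-c2nn(-c3cccc(NC(=O)Nc4cccc(C(F)(F)F)c4)c3)cc2-c2ccncc2)ccc1Cl`, a functional assay on K562 cells (Homo sapiens) for inhibition, read by sulforhodamine B assay, with a stated time of 48 h; on this read-out higher numbers stand for weaker inhibition of growth and lower numbers for stronger inhibition of growth: 584 nM
Compound 2 `COc1cc(-c2nn(-c3cccc(NC(=O)c4ccc(Cl)c(C(F)(F)F)c4)c3)cc2-c2ccncc2)ccc1Cl`, this assay: 1610 nM

Within the data shown here, compound 2 carries the highest number of the two measured compounds; the only neighbour is compound 1, which sits at a lower number, beyond the scatter. Compound 3 `COc1cc(-c2nn(-c3cccc(NC(=O)c4ccccc4)c3)cc2-c2ccncc2)ccc1Cl` is not yet measured. It differs from compound 2 by phenyl in place of 4-chloro-3-(trifluoromethyl)phenyl on a carbonyl carbon.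

Among the measured compounds shown here, no measured step bears directly on this change. For the measured compounds named here, the single step, a 2.8-fold higher number from compound 1 to compound 2 (0.44 log units; beyond the scatter), swaps the group on the carbonyl carbon together with its linkage and so cannot separate the effect of the chlorine and trifluoromethyl groups from that of the urea-to-amide switch. With the tail stripped to a bare phenyl, the expectation is a further modest rise in number, a 2.2-fold higher number from compound 2 to compound 3 (0.34 log units; beyond the scatter), though the uncertainty is wide. Compound 3 is therefore estimated at 3500 nM, within 1200 nM to 10000 nM.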

Compound 3, concentration for 50% growth inhibition: 421 nM
Beside the measured number, compound 3's estimate is 8.3-fold (0.92 log units) above it; the whole stated range lies above it.
By their numbers in this assay, from the lowest: compounds 3 and 1 (each within the scatter of the next); then compound 2.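

In this assay, phenyl in place of 4-chloro-3-(trifluoromethyl)phenyl on the amide carbonyl carbon gives a 3.8-fold lower number from compound 2 to compound 3 (0.58 log units; beyond the scatter), so this amide does not need the chlorine and trifluoromethyl groups for growth inhibition, and carrying both goes with the weaker number of the pair. The phenyl amide and the urea are level, with a 1.4-fold lower number from compound 1 to compound 3 (0.14 log units; within the scatter), so the 3-(trifluoromethyl)phenyl urea tail of compound 1 shows no gain over the bare phenyl amide of compound 3. No evidence is available that accounts for either step.

As far as these compounds go, the chlorine and the trifluoromethyl group leave together, so their separate contributions to the higher number of compound 2 remain open. Also open, from the compounds shown here alone, is how an amine or a carboxylic acid on the phenyl of compound 3 would shift the number in this assay, and whether a longer chain on the carbonyl carbon would be tolerated.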